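This account rests on a few compounds, and the source may have more. Where it says the series, first, only, none or still open, it means among the compounds named here.

Measured so far in a functional assay (aorta) with Rattus norvegicus as the target; a higher number here means a weaker inhibitor, a lower number a stronger inhibitor:
Compound 1 (`CC1(C)Oc2ccc(C#N)cc2[C@@H](/N=C(\NC#N)Nc2cccc(C(F)(F)F)c2)[C@@H]1O`): 1600 nM
Compound 2 (`CC(=O)c1cccc(N/C(=N/[C@@H]2c3cc(C#N)ccc3OC(C)(C)[C@H]2O)NC#N)c1`): 8400 nM

Of these two, compound 2 has the higher number, 8400 nM, and so is the weaker inhibitor in this assay. Within the data shown here, the only measured step, a 5.3-fold higher number from compound 1 to compound 2 (0.72 log units; beyond the scatter), put acetyl in place of trifluoromethyl on an aromatic carbon. It is modest but beyond the scatter.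

The next compound, compound 3 (`COc1ccc(N/C(=N/[C@@H]2c3cc(C#N)ccc3OC(C)(C)[C@H]2O)NC#N)cc1`), differs from compound 2 in one place: 4-methoxyphenyl in place of 3-acetylphenyl on an amine nitrogen. Here 4-methoxyphenyl takes the place of 3-acetylphenyl on an amine nitrogen, while the shared core stays unchanged.

Among the measured compounds shown here, the single measured step bears on this change only in part. For the measured compounds named here, it also concerns the acetyl group, but no measured compound carries 4-methoxyphenyl, so the data give no direction. That step, a 5.3-fold higher number from compound 1 to compound 2 (0.72 log units; beyond the scatter), therefore serves only as a rough guide to size, and a shift of similar size either way remains possible. The expected change is a 1.4-fold lower number from compound 2 to compound 3 (0.15 log units; within the scatter), an estimated step that does not clearly exceed the scatter. For compound 3 the estimated value is 6000 nM, with an expected range from 2000 nM to 18000 nM.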

Compound 3, half-maximal inhibitory concentration: 32500 nM
Beside the measured number, compound 3's estimate is 5.4-fold (0.73 log units) below it; the measured number lies above the stated range.
By their numbers in this assay, from the lowest: compound 1; then compound 2; then compound 3.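

Across this assay, the group on this amine nitrogen now spans a wider range: there is a 3.9-fold higher number from compound 2 to compound 3 (0.59 log units; beyond the scatter) and a 20-fold higher number from compound 1 to compound 3 (1.31 log units; beyond the scatter), which makes compound 3 the weakest inhibitor of the three. Among these compounds, the order at this position, from the lowest number, is now 3-(trifluoromethyl)phenyl, 3-acetylphenyl and 4-methoxyphenyl, so the new group gives a higher number than either group carried by the earlier compounds. No measurement at hand gives a reason for this order.

In both new steps the substituent and its printed ring number change together, so the compounds shown cannot tell whether the higher number goes with methoxy itself or with its place at 4. A 3-methoxyphenyl group or a plain phenyl group on the same amine nitrogen would help to separate these two readings, and it remains open how either would compare with the three groups shown here.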